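Phenyl substituent changes on the shared core

The source may report more compounds than this note shows. Statements on the series, on what has been measured and on what is new or still open speak of the compounds shown alone.

Compound 3 `Cn1cc(/C=C2/C(=O)Nc3ccccc32)c2cc(Nc3nccc(-c4ccc(O)cc4)n3)ccc21` carries a hydroxy on the phenyl ring of the shared core. In a functional assay on MCF7 cells (Homo sapiens) for cytotoxicity, read by MTT assay, with a stated time of 48 h (a higher number here means a weaker inhibitor, a lower number a stronger inhibitor), compound 3 gives 39600 nM, the lowest of the two numbers in hand, though only within the scatter of compound 1 `Cn1cc(/C=C2/C(=O)Nc3ccccc32)c2cc(Nc3nccc(-c4ccccc4)n3)ccc21`, the unsubstituted parent, which gives 42900 nM. Compound 2 `Cc1ccc(-c2ccnc(Nc3ccc4c(c3)c(/C=C3/C(=O)Nc5ccccc53)cn4C)n2)cc1`, with a methyl on that phenyl ring, reaches only the upper limit of this assay at > 100000 nM. That limit is where one of the three values sits (the limit of > 100000 nM in this assay, at which 1 of the 3 values shown sits). The methyl step reads an at least 2.3-fold higher number from compound 1 to compound 2 (0.36 log units; beyond the scatter), the hydroxy step a 1.1-fold lower number from compound 1 to compound 3 (0.03 log units; within the scatter), and between the two substituted compounds an at least 2.5-fold lower number from compound 2 to compound 3 (0.40 log units; beyond the scatter).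

Compound 4 `Cn1cc(/C=C2/C(=O)Nc3ccccc32)c2cc(Nc3nccc(-c4ccc(Cl)cc4)n3)ccc21` differs from compound 3 by chloro in place of hydroxy on an aromatic carbon. For the measured compounds named here, no measured step exchanges hydroxy for chloro. The nearest pair is compound 1 to compound 3, where hydroxy for hydrogen left the number within the scatter, while compound 1 to compound 2 shows that a methyl on the same ring pushed the value beyond the limit. The step is therefore expected to read a 1.4-fold higher number from compound 3 to compound 4 (0.14 log units; within the scatter), with a fair chance that only a limit is returned. Compound 4 is estimated at 55000 nM, with a range from 22000 nM to 130000 nM.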

Compound 4, half-maximal inhibitory concentration: 23500 nM
Compound 4: the middle estimate sits 2.3-fold (0.37 log units) above what was measured, and the stated range covers the measured number.
By their numbers in this assay, from the lowest: compounds 4, 3 and 1 (each within the scatter of the next). At a limit, above all of these: compound 2.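

With chloro at this position, para to a large group, compound 4 does not separate from the two compounds that carry hydroxy or hydrogen there in this assay: the readings are a 1.7-fold lower number from compound 3 to compound 4 (0.23 log units; within the scatter) and a 1.8-fold lower number from compound 1 to compound 4 (0.26 log units; within the scatter). Against methyl the picture differs, with an at least 4.2-fold lower number from compound 2 to compound 4 (0.62 log units; beyond the scatter), so the result for compound 2 does not extend to every replacement of hydrogen on this ring, and compounds 3 and 4 both go against such a pattern. Compound 2 is a limit and not a number, which leaves the full size of that step unknown: the limit of > 100000 nM in this assay, at which 1 of the 4 values shown sits.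

The compounds shown leave open whether the compound 2 result belongs to methyl alone or would recur with a longer chain such as ethyl or with methoxy, and whether an amine or a carboxylic acid at this position would move the number beyond the scatter of compounds 1, 3 and 4. From the compounds shown here alone, whether compounds 1, 3 and 4 would also stay this close in a different cell line remains open as well.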